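The source may report more compounds than this note shows. Statements on the series, on what has been measured and on what is new or still open speak of the compounds shown alone.

Compound 1 `O=C(Nc1ccc(-n2ccc3nc(C(=O)NCc4ccccc4)ccc32)cc1)Nc1cccc(Cl)c1Cl` is known only through a limit: in a functional assay on A375P cells (Homo sapiens) for cytotoxicity, read by MTT assay (on this read-out lower numbers stand for stronger inhibition and higher numbers for weaker inhibition), compound 1 reads > 10000 nM, which is a limit of the assay (the limit of > 10000 nM in this assay, at which 1 of the 2 values shown sits). For the measured compounds named here, compound 2 `COC(=O)c1ccc2c(ccn2-c2ccc(NC(=O)Nc3cccc(Cl)c3Cl)cc2)n1` carries methoxy in place of benzylamino on a carbonyl carbon; in this assay compound 2 gives 6400 nM, and the step of an at least 1.5-fold lower number from compound 1 to compound 2 (0.19 log units; that floor lies within the scatter) is the only measured step. Compound 3 `O=C(Nc1ccc(-n2ccc3nc(C(=O)NCc4ccccc4)ccc32)cc1)c1cccc(C(F)(F)F)c1` differs from compound 1 at the other end of the molecule: 3-(trifluoromethyl)phenyl in place of (2,3-dichlorophenyl)amino on a carbonyl carbon, so that (2,3-dichlorophenyl)carbamoyl becomes (3-(trifluoromethyl)phenyl)carbonyl. Going by the values given here, no measured step touches this position; the one known step concerns a different carbonyl carbon and its floor lies within the scatter, so it sets no direction here. Compound 1 stands at a limit, which leaves the starting point itself open. For compound 3 the expectation is a number close to that limit, a number no higher from compound 1 to compound 3 (the limit leaves the size open), estimated at 10000 nM with a range of 2500 nM to 40000 nM, and with a real chance that only a limit is reported again.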

Compound 3, half-maximal inhibitory concentration: 3000 nM
For compound 3 the middle estimate is 3.3-fold (0.52 log units) above the measured one; measured number inside the range.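

Replacing (2,3-dichlorophenyl)amino with 3-(trifluoromethyl)phenyl on a carbonyl carbon gives, in this assay, an at least 3.3-fold lower number from compound 1 to compound 3 (0.52 log units; beyond the scatter). For the compounds shown here, this is the first step printed as beyond the scatter, and it shows that this position can move the read-out while benzylamino stays in place. As far as these compounds go, compound 1 is held only at a limit of the assay, so the true size of the step stays open: the limit of > 10000 nM in this assay, at which 1 of the 3 values shown sits.

The change swaps the ring substituents and also removes the hydrogen-bond donor of the leaving group, and the compounds shown do not separate these two differences. Open as well are the reading with an unsubstituted phenyl or a methylamino group on this carbonyl carbon, and whether 3-(trifluoromethyl)phenyl gives a similar step when methoxy replaces benzylamino.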